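A Nitrogen Swap from Cyclohexyl to 4-Methylphenyl

The compounds below may be only part of what the source reports. "The series", "measured", "known", "first", "only" and "open" are said of these compounds alone.

In a functional assay on HCT-116 cells (Homo sapiens) for antiproliferative activity, read by MTT assay, with a stated time of 72 h (on this read-out higher numbers stand for weaker inhibition and lower numbers for stronger inhibition), compound 1 `CC(C)N1C(=O)COc2ccc(-c3cccc(NS(=O)(=O)c4ccc(F)cc4)c3)cc21` gives 22600 nM and compound 2 `O=C1COc2ccc(-c3cccc(NS(=O)(=O)c4ccc(F)cc4)c3)cc2N1C1CCCCC1` gives 18300 nM on the same scale, so compound 2 stands level with compound 1 within the scatter. Compound 3 `Cc1ccc(N2C(=O)COc3ccc(-c4cccc(NS(=O)(=O)c5ccc(F)cc5)c4)cc32)cc1` keeps the shared core and carries 4-methylphenyl in place of cyclohexyl on an amide-type nitrogen in a ring. For the measured compounds named here, one measured step bears on this change. Placing cyclohexyl on that same nitrogen instead of isopropyl gave a 1.2-fold lower number from compound 1 to compound 2 (0.09 log units; within the scatter) and this lies within the scatter. Going by the values given here, no aromatic group has yet been measured at this nitrogen, so that single step is only a loose guide. No change beyond the scatter is therefore expected in this assay for this swap. The expected step is a 1.1-fold lower number from compound 2 to compound 3 (0.06 log units; within the scatter) and it carries a wide margin. For compound 3 the estimated value is 16000 nM with an expected range from 6000 nM to 40000 nM on this read-out.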

Compound 3, half-maximal inhibitory concentration: 35600 nM
Estimate against measurement, compound 3: 2.2-fold (0.35 log units) below; the measured number falls inside the stated range.
By their numbers in this assay, from the lowest: compounds 2, 1 and 3 (each within the scatter of the next).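

Compound 3 brings an aromatic ring onto the amide-type nitrogen for the first time among these compounds, and in this assay this swap gives a 1.9-fold higher number from compound 2 to compound 3 (0.29 log units; within the scatter) and still stays within the usual scatter. Measured against the isopropyl group, the same 4-methylphenyl gives a 1.6-fold higher number from compound 1 to compound 3 (0.20 log units; within the scatter), so a branched chain, a saturated ring and an aromatic ring all read alike here, and this position has so far shown no clear preference among these three groups. Nothing on hand accounts for this flat result.

As far as these compounds go, it remains open whether any group on this nitrogen can move the number beyond the scatter. A chain ending in an amine, a chain ending in a carboxylic acid or a plain phenyl ring would test this further.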